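Chain extension with a hydroxyl on the shared core

The source may hold more compounds than are shown below. What is called first, only, known or untested is meant among the compounds shown, and "the series" means these compounds.

Going by the values given here, compound 2 `CCn1cc(-c2n[nH]c3cc(-c4cc(C(=O)Nc5cccc(C(F)(F)F)c5)ccc4C)ccc23)cn1` gives 2.6 nM in an assay on isolated protein for inhibition of Discoidin domain-containing receptor 2 (Homo sapiens), read by ELISA, with a stated time of 60 min (on this read-out higher numbers stand for weaker inhibition and lower numbers for stronger inhibition), the lower of the two numbers measured so far; compound 1 `Cc1ccc(C(=O)Nc2cccc(C(F)(F)F)c2)cc1-c1ccc2c(-c3cnn(C)c3)n[nH]c2c1` gives 4.4 nM, and the step of a 1.7-fold lower number from compound 1 to compound 2 (0.23 log units; within the scatter) is within the scatter, so the two compounds are not separated. Compound 3 `Cc1ccc(C(=O)Nc2cccc(C(F)(F)F)c2)cc1-c1ccc2c(-c3cnn(CC(C)O)c3)n[nH]c2c1` carries 1-hydroxyethyl in place of methyl on a saturated chain carbon bound to an aromatic nitrogen, so that 1-ethyl-1H-pyrazol-4-yl becomes 1-(2-hydroxypropyl)-1H-pyrazol-4-yl. Among the compounds with values here, only one measured step bears on this place, a 1.7-fold lower number from compound 1 to compound 2 (0.23 log units; within the scatter), and it stayed within the scatter: the group on the saturated chain carbon bound to an aromatic nitrogen has so far not moved the number. Within the data shown here, no measured pair shows a hydroxyl entering anywhere, so the effect of the added hydrogen-bond donor and acceptor is unknown. The expected step is therefore small, a 1.2-fold higher number from compound 2 to compound 3 (0.06 log units; within the scatter), with no movement beyond the scatter. The estimate for compound 3 in this assay is 3 nM, with a range from 1.2 nM to 8 nM to cover the open question of the hydroxyl.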

Compound 3, half-maximal inhibitory concentration: 3.7 nM
Beside the measured number, compound 3's estimate is 1.2-fold (0.09 log units) below it; the range from low to high includes it.
By their numbers in this assay, from the lowest: compounds 2, 3 and 1 (each within the scatter of the next).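

In this assay, a hydroxyl now enters the series at this place, and the number stays within the scatter: 1-hydroxyethyl in place of methyl on a saturated chain carbon bound to an aromatic nitrogen gives a 1.4-fold higher number from compound 2 to compound 3 (0.15 log units; within the scatter), and 1-hydroxyethyl in place of hydrogen at that carbon gives a 1.2-fold lower number from compound 1 to compound 3 (0.08 log units; within the scatter). Compound 1, compound 2 and compound 3 are therefore not separated, so the earlier reading that this place does not move the number now extends from a change of one carbon to 2-hydroxypropyl, a chain that brings one hydrogen-bond donor and one hydrogen-bond acceptor. No supporting measurement bears on this flat result.

From the compounds shown here alone, only neutral chains appear at this place, so it remains open whether a terminal amine, a carboxylic acid or a longer chain such as 3-hydroxybutyl would leave the number within the scatter. With a single hydroxyl-bearing chain in hand, the compounds shown also cannot tell whether the hydroxyl and the added carbons of 2-hydroxypropyl each leave the number unmoved when taken separately.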